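Swapping the aryl amine on a glutarimide-isoindolinone core

The compounds below may be only part of what the source reports. "The series", "measured", "known", "first", "only" and "open" are said of these compounds alone.

Measured compounds:
compound 1, `O=C1CCC(N2C(=O)c3ccc(Nc4ccccn4)cc3C2=O)C(=O)N1`, 9%
compound 2, `O=C1CCC(N2C(=O)c3cccc(Nc4ccccc4)c3C2=O)C(=O)N1`, 4%
compound 3, `O=C1CCC(N2C(=O)c3cccc(Nc4ccccn4)c3C2=O)C(=O)N1`, 1%

Of the compounds shown here, three sharing one core have been tested in an assay on FRT-Jurkat cells for inhibition of nuclear factor NF-kappa-B complex (Homo sapiens), read by flow cytometry, with a stated time of 24 h, tested at 10 uM; on this read-out lower numbers stand for less inhibition and higher numbers for more inhibition at the one concentration tested (going by the name of the read-out). Compound 1 gives 9%, the largest of the three numbers, but compound 2 with 4% and compound 3 with 1% both sit within the scatter of it, so none of the three can be set apart from the others.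

Compound 4, `O=C1CCC(N2C(=O)c3ccc(Nc4ccc(O)cc4)cc3C2=O)C(=O)N1`, has not yet been measured. It differs from compound 1 in one place: 4-hydroxyphenyl in place of pyridin-2-yl on a nitrogen on an aromatic ring. Within the data shown here, the only measured step that touches a similar exchange is a number 3 percentage points lower from compound 2 to compound 3 (within the scatter), where a pyridin-2-yl replaced a phenyl on the same kind of nitrogen, though attached at a different position of the core. That step was small, and the three measured numbers as a whole are low and close together. Among the measured compounds shown here, for compound 4 the expectation is therefore no step beyond the scatter, no change at the digits printed from compound 1 to compound 4 (within the scatter), with the caveat that no measured pair carries a hydroxyl on the outer ring.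

Compound 4 is expected to give 9% in this assay, within a range from 0% to 24%.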

Compound 4, a percentage reported as inhibition, at one concentration (the size of the read-out at that concentration, not a potency): 4%
Compound 4: the middle estimate sits 5 percentage points above what was measured; measured number inside the range.
By their numbers in this assay, from the lowest: compounds 3, 2, 4 and 1 (each within the scatter of the next).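

Among these compounds, the step of a number 5 percentage points lower from compound 1 to compound 4 (within the scatter) in this assay is the first measured exchange at this attachment point of the core, since the earlier step between compound 2 and compound 3 lay at a different position. It also brings in the first hydroxyl on the outer ring, and with it a hydrogen-bond donor that pyridin-2-yl does not carry, yet this larger exchange of a ring containing nitrogen for a carbon-only ring with a hydroxyl stays within the scatter, just as the smaller exchange did. Nothing available explains why the number stays within the scatter, and the two parts of the exchange, the ring nitrogen lost and the hydroxyl gained, cannot be told apart from this one pair.

Still open, on these data alone, is whether any outer group on this nitrogen can lift the number in this assay beyond the scatter, since all four compounds lie close together. A carboxylic acid or a primary amine on the outer ring, or a longer chain in place of the ring, would probe this position in ways that the compounds shown do not.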